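Ethyl for Nitrophenyl in Three Analogues Without Measurable Effect

The source may hold more compounds than are shown below. What is called first, only, known or untested is meant among the compounds shown, and "the series" means these compounds.

Three compounds sharing one core were tested in a functional assay on aorta with Alpha-1D adrenergic receptor (Rattus norvegicus) as the target; a higher number here means that more compound is needed for the effect, a lower number that less compound is needed. Compound 1 `CCn1nc(Cc2ccc(SC)cc2)c2ccccc2c1=O` gives > 100000 nM, which is a limit of the assay rather than a number. Compound 2 `CSc1ccc(Cc2nn(-c3ccc([N+](=O)[O-])cc3)c(=O)c3ccccc23)cc1` likewise stops at a limit of the assay with > 100000 nM. Compound 3 `COc1ccc(Cc2nn(-c3ccc([N+](=O)[O-])cc3)c(=O)c3ccccc23)cc1OC` also reaches only a limit of the assay, > 100000 nM. Compound 2 and compound 1 differ by ethyl in place of 4-nitrophenyl on an aromatic nitrogen. The step that the two limits leave unreadable from compound 2 to compound 1 cannot be sized since both values are limits. The cores of compound 2 and compound 3 differ by 3,4-dimethoxyphenyl in place of 4-(methylsulfanyl)phenyl on a saturated chain carbon bound to an aromatic carbon. The step that the two limits leave unreadable from compound 2 to compound 3 is equally unreadable. Among the measured compounds shown here, compound 4 `CCn1nc(Cc2ccc(OC)c(OC)c2)c2ccccc2c1=O`, not yet measured, differs from compound 3 by ethyl in place of 4-nitrophenyl on an aromatic nitrogen, the same kind of change as the one made from compound 2 to compound 1, though the surroundings differ: in compound 2 the place is meta to a 4-(methylsulfanyl)benzyl group (9 heavy atoms), in compound 3 it is meta to a large group. Because the three measured values all sit at the limit of > 100000 nM in this assay, at which 3 of the 3 values shown sit, the expected step is a step that the limit leaves unreadable from compound 3 to compound 4, essentially none. Compound 4 is therefore estimated at 150000 nM, most likely again only a limit, with a range from 40000 nM to 1000000 nM.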

Compound 4, half-maximal effective concentration: 5300 nM
For compound 4 the middle estimate is 28-fold (1.45 log units) above the measured one; the measured number lies below the stated range.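

In this assay, ethyl in place of 4-nitrophenyl on the aromatic nitrogen gives an at least 18-fold lower number from compound 3 to compound 4 (1.27 log units; beyond the scatter), a large change in the core that carries the 3,4-dimethoxyphenyl group. With the 4-(methylsulfanyl)phenyl group, the same exchange yields no number, and compound 1 remains at a limit of the assay, > 100000 nM. This shows that the gain seen in compound 4 does not carry over to the other core in any readable form, but it does not show how large the effect of the change is there, and the other steps cannot be read at all because they have no number at either end: the limit of > 100000 nM in this assay, at which 3 of the 4 values shown sit.

Among the compounds shown here, compound 4 is the only compound here with a measured number, so a single pair cannot show whether the gain comes from having ethyl or from losing 4-nitrophenyl. On these data alone, it also remains open whether a longer chain such as butyl, or a chain ending in an amine, on the same nitrogen would lower the number further.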